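The compounds below may be only part of what the source reports. "The series", "measured", "known", "first", "only" and "open" are said of these compounds alone.

Measured so far:
compound 1 `COc1nn(Cc2ccccc2-c2ccccc2)c(=O)o1` — 23%
compound 2 `COc1nn(Cc2ccccc2[N+](=O)[O-])c(=O)o1` — 36%

In an assay on COS-7 cells for inhibition of Fatty-acid amide hydrolase 1 (Homo sapiens), read by scintillation counting, with a stated time of 10 min, tested at 10 uM (a lower number here means less inhibition, a higher number more inhibition at the concentration tested (going by the name of the read-out)), compound 2 gives 36%, the higher of the two numbers; compound 1 gives 23%, so the step of a number 13 percentage points higher from compound 1 to compound 2 (beyond the scatter) is modest but beyond the scatter. Compound 3 `COc1nn(Cc2ccccc2N)c(=O)o1` differs from compound 2 by amino in place of nitro on an aromatic carbon. Going by the values given here, the only measured step, a number 13 percentage points higher from compound 1 to compound 2 (beyond the scatter), puts nitro in place of phenyl and says nothing directly about amino, so the direction of the change is unanchored. A step within the scatter, or a small drop, is expected: a number 8 percentage points lower from compound 2 to compound 3 (within the scatter). Compound 3 is therefore estimated at 28%, range 10% to 46%.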

Compound 3, a percentage reported as inhibition, at one concentration (the size of the read-out at that concentration, not a potency): 8%
Compound 3: the middle estimate sits 20 percentage points above what was measured; the whole stated range lies above it.
By their numbers in this assay, from the lowest: compound 3; then compound 1; then compound 2.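

In this assay amino in place of nitro gives a number 28 percentage points lower from compound 2 to compound 3 (beyond the scatter) and amino in place of phenyl gives a number 15 percentage points lower from compound 1 to compound 3 (beyond the scatter) so amino stands lowest of the three groups at this place. The earlier pair showed only a rise with nitro; this aromatic carbon now also shows a fall with amino. Nothing available explains the fall.

Open, on these data alone, is whether an acetamide or a carboxylic acid at this place would stand nearer to nitro or to amino. Also open, as far as these compounds go, is how a methoxy group here would compare.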